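This account rests on a few compounds, and the source may have more. Where it says the series, first, only, none or still open, it means among the compounds named here.

Compound 3, `O=C(/C=C\Nc1ccc(Cl)cc1)c1nc(-c2ccc(C(F)(F)F)cc2)n2ccccc12`, is the reference point here. Among the compounds with a number in a functional assay on MDA-MB-231 cells (Homo sapiens) for cytotoxicity, read by MTT assay, with a stated time of 48 h (a lower number here means a stronger inhibitor, a higher number a weaker inhibitor), compound 3 gives 3840 nM, the lowest value shown. Compound 1, `O=C(/C=C\Nc1ccc(F)cc1)c1nc(-c2ccc(F)cc2)n2ccccc12`, which carries a fluoro on each of its two outer rings, gives 25100 nM in this assay, a higher number than compound 3 by a margin that lies beyond the scatter. Compound 2, `COc1ccc(-c2nc(C(=O)/C=C\Nc3ccc(Cl)cc3)c3ccccn23)cc1`, reaches only a limit of this assay, > 30000 nM, and no number. Among the measured compounds shown here, the one measured step that bears on this question runs an at least 7.8-fold lower number from compound 2 to compound 3 (0.89 log units; beyond the scatter), where the value of compound 2 is itself a limit, (the limit of > 30000 nM in this assay, at which 1 of the 3 values shown sits). Compound 4, `O=C(/C=C\Nc1ccc(Cl)cc1)c1nc(-c2ccc(F)cc2)n2ccccc12`, differs from compound 3 by fluoro in place of trifluoromethyl on an aromatic carbon. Since moving from methoxy to trifluoromethyl lowered the number in this assay, the reverse direction toward a smaller group is expected to raise it; compound 1, which also carries a fluorophenyl, is the closest guide with 25100 nM. The change a 5.2-fold higher number from compound 3 to compound 4 (0.72 log units; beyond the scatter) is therefore expected to be a clear rise. Compound 4 is estimated at 20000 nM, with a range from 7000 nM to 50000 nM.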

Compound 4, half-maximal inhibitory concentration: 4250 nM
The estimate for compound 4 lay 4.7-fold (0.67 log units) above the measured number; the measured number lies below the stated range.
By their numbers in this assay, from the lowest: compounds 3 and 4 (each within the scatter of the next); then compound 1. At a limit, above all of these: compound 2.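

Compound 4 shows that at this aromatic carbon, para to a large group, fluoro and trifluoromethyl cannot be told apart in this assay, with a 1.1-fold higher number from compound 3 to compound 4 (0.04 log units; within the scatter), even though the group shrinks from 4 heavy atoms to 1. So the earlier drop on leaving methoxy did not need trifluoromethyl itself, as fluoro also stands well clear of methoxy, with an at least 7.0-fold lower number from compound 2 to compound 4 (0.84 log units; beyond the scatter); compound 4 also gives the first clean reading of the other outer ring, where chloro in place of fluoro comes with a 5.9-fold lower number from compound 1 to compound 4 (0.77 log units; beyond the scatter). The comparisons with compound 2 give only a minimum size, as compound 2 has a limit and not a number: the limit of > 30000 nM in this assay, at which 1 of the 4 values shown sits.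

Going by these compounds, whether this tolerance extends to groups of a different kind at the same place, such as an amine, a carboxylic acid or a nitrile, stays open, and so does how a hydrogen would compare there. Also open, on these data alone, is whether the advantage of chloro over fluoro on the other outer ring would persist with trifluoromethyl on the first ring, or would extend to bromo.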